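Swapping the ring substituent: from ethylamino to carbamoyl

The source may report more compounds than this note shows. Statements on the series, on what has been measured and on what is new or still open speak of the compounds shown alone.

Of the compounds shown here, three sharing one core have been tested in an assay on isolated protein (strain Sprague-Dawley) for inhibition of Amine oxidase [flavin-containing] B (Rattus norvegicus), read by spectrophotometry, with a stated time of 5 min; a higher number here means a weaker inhibitor, a lower number a stronger inhibitor. Compound 1 `NC(=O)COc1cc(=O)oc2cc(OCc3cccc(Cl)c3)ccc12` gives 3.1 nM; 3.31 nM (2 entries), compound 2 `CCOC(=O)Nc1cc(=O)oc2cc(OCc3cccc(Cl)c3)ccc12` gives 589 nM, and compound 3 `CCNc1cc(=O)oc2cc(OCc3cccc(Cl)c3)ccc12` gives 28.2 nM. Within the data shown here, compound 3 therefore has the lower of the two single numbers, with compound 2 a long way behind; the one measured step, a 21-fold lower number from compound 2 to compound 3 (1.32 log units; beyond the scatter), is large. Compound 4 `NC(=O)c1cc(=O)oc2cc(OCc3cccc(Cl)c3)ccc12` differs from compound 3 as follows: carbamoyl in place of ethylamino on an aromatic carbon. Among the measured compounds shown here, no measured step changes the group on that aromatic carbon itself, so the large step from compound 2 to compound 3 bears only loosely on this change. For compound 4 in this assay the expected step is a 1.9-fold lower number from compound 3 to compound 4 (0.27 log units; within the scatter), which is modest. Compound 4 is thus estimated at 15 nM, within a range of 3 nM to 80 nM.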

Compound 4, half-maximal inhibitory concentration: 234 nM
Estimate against measurement, compound 4: 16-fold (1.19 log units) below; measured number above the stated range.
By their numbers in this assay, from the lowest: compound 3; then compound 4; then compound 2.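

On this aromatic carbon, the same count of heavy atoms and of hydrogen-bond donors and acceptors does not mean the same number: replacing ethylamino with carbamoyl gives a clear loss (an 8.3-fold higher number from compound 3 to compound 4 (0.92 log units; beyond the scatter)). Carbamoyl still beats (ethoxycarbonyl)amino (a 2.5-fold lower number from compound 2 to compound 4 (0.40 log units; beyond the scatter)), which places compound 4 between the other two compounds. Nothing measured here explains why these groups differ.

Open, as far as these compounds go, is how a carboxylic acid, a plain amine or a longer chain on this carbon would compare. Also open, from the compounds shown here alone, is whether a methylamino group would keep the low number of compound 3.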